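From cyclopropyl to ethyl at one carbonyl carbon

A few compounds are considered here, and "the series" means these few. Any claim that something is new, unique, unknown or untested is made for them only; others in the source may bear on it.

For the measured compounds named here, in a physicochemical assay for solubility, read by mass spectrometry, in phosphate buffer, with a stated time of 24 h, at pH 7.4 (on this read-out lower numbers stand for lower solubility and higher numbers for higher solubility), compound 1 (`O=C(Nc1ccc(OC(F)(F)F)c(F)c1)NC1CCN(C(=O)C2CC2)CC1`) gives 19 ug/mL, the lowest of the three numbers so far. Compound 2 (`O=C(Nc1ccc(OC(F)(F)F)cc1)NC1CCN(C(=O)C2CCOCC2)CC1`) gives 91 ug/mL and compound 3 (`O=C(CC1CCN(C(=O)C2CC2)CC1)Nc1ccc(OC(F)(F)F)c(F)c1`) gives 715 ug/mL, and both gaps to compound 1 lie beyond the usual scatter of repeated measurements. Compound 4 (`CCC(=O)N1CCC(NC(=O)Nc2ccc(OC(F)(F)F)c(F)c2)CC1`) has ethyl in place of cyclopropyl on a carbonyl carbon. Going by the values given here, no measured pair shows this swap, so the forecast rests on the modest size of the change alone. The expected step is a 1.5-fold higher number from compound 1 to compound 4 (0.17 log units; within the scatter), slightly upward and within the scatter. For compound 4, the estimated value is 28 ug/mL, with a likely range of 10 ug/mL to 80 ug/mL.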

Compound 4, solubility: 11 ug/mL
Compound 4: middle estimate off by 2.5-fold (0.41 log units), on the high side; the range from low to high includes it.
By their numbers in this assay, from the lowest: compounds 4 and 1 (each within the scatter of the next); then compound 2; then compound 3.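

For the compounds shown here, putting ethyl in place of cyclopropyl on the carbonyl carbon gives the first measured pair that differs only at this position. In this assay the step is small (a 1.7-fold lower number from compound 1 to compound 4 (0.24 log units; within the scatter)), so compound 1 and compound 4 cannot be told apart. In this one pair, opening the three-membered ring and losing one carbon leaves no change that can be read beyond the scatter, and no measurement at hand explains the result.

As far as these compounds go, whether a longer chain or an amine on this carbonyl carbon would give a step beyond the scatter stays open. So does whether the same swap would give a similarly small step on another core.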